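From Methylamino to 4-Carbamoylpiperidin-1-yl in Compound 4

This account rests on a few compounds, and the source may have more. Where it says the series, first, only, none or still open, it means among the compounds named here.

Of the compounds shown here, three have been measured in a functional assay on PC-3 cells (Homo sapiens) for cytotoxicity, read by MTT assay, with a stated time of 48 h; a lower number here means a stronger inhibitor, a higher number a weaker inhibitor. Compound 1, `CC1=NN(C(=O)/C=C/c2ccccc2)C(c2ccccc2O)C1`, gives 42000 nM in this assay. Compound 2, `CC(=O)Oc1ccccc1C1CC(C)=NN1C(=O)CN1CCC(O)CC1`, gives 25600 nM. Compound 3, `CNCC(=O)N1N=C(c2cc3ccccc3oc2=O)CC1c1ccccc1`, gives 2300 nM, the lowest of the three numbers, and its gaps to compound 2 and to compound 1 both lie beyond the usual scatter, so compound 3 is the strongest inhibitor among them. Going by the values given here, no pair of these measured compounds differs in a single place, so the data offer no isolated step to learn from.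

Compound 4, `NC(=O)C1CCN(CC(=O)N2N=C(c3cc4ccccc4oc3=O)CC2c2ccccc2)CC1`, is the next compound to be tested. It differs from compound 3 in one place: 4-carbamoylpiperidin-1-yl in place of methylamino on a saturated chain carbon bound to a carbonyl carbon. The change keeps the rest of compound 3 intact and enlarges only the group on the saturated chain carbon bound to the carbonyl carbon. Among the compounds with values here, with no measured step of this kind to lean on, the account expects a step of a 1.5-fold higher number from compound 3 to compound 4 (0.18 log units; within the scatter), small and within or near the scatter, leaning slightly toward a weaker inhibitor. Compound 4 is therefore estimated at 3500 nM in this assay, with a range from 1200 nM to 10000 nM.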

Compound 4, half-maximal inhibitory concentration: 8310 nM
Compound 4: middle estimate off by 2.4-fold (0.38 log units), on the low side; low and high end bracket the measured number.
By their numbers in this assay, from the lowest: compound 3; then compound 4; then compounds 2 and 1 (each within the scatter of the next).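

In this assay, the exchange of methylamino for 4-carbamoylpiperidin-1-yl gives a 3.6-fold higher number from compound 3 to compound 4 (0.56 log units; beyond the scatter), the first single-place change among these compounds. It shows that the group on the saturated chain carbon bound to a carbonyl carbon matters in this series: with the rest of the molecule unchanged, the larger group, which has 9 heavy atoms in place of 2, gives a weaker inhibitor by a modest step that lies beyond the scatter. No available evidence bears on what lies behind this step.

The compounds shown leave open whether the higher number goes with the six-membered ring, with the carbamoyl group it carries, or with the overall enlargement, as this position is represented by a single step on this core. As far as these compounds go, a plain piperidin-1-yl group, a dimethylamino group or a piperidine bearing a carboxylic acid in place of the carbamoyl group would each separate these readings, and how any of them would behave at this position remains unknown.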